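Swapping a Biaryl Ketone for a Furan

The compounds below may be only part of what the source reports. "The series", "measured", "known", "first", "only" and "open" are said of these compounds alone.

Compound 1 `CN(CC1=CC[C@H]2C[C@@H]1C2(C)C)Cc1ccc(Br)cc1` carries a bromo on an aromatic carbon, and in an assay on HEK293 cells for displacement of a labelled ligand from C-X-C chemokine receptor type 3 (Homo sapiens) (a higher number here means a weaker inhibitor, a lower number a stronger inhibitor), compound 1 gives 3160 nM. Compound 2 `CC(=O)c1cccc(-c2ccc(CN(C)CC3=CC[C@H]4C[C@@H]3C4(C)C)cc2)c1` has 3-acetylphenyl in place of that bromo. In this assay compound 2 gives only a limit, > 316 nM. The step that the limit leaves unreadable from compound 1 to compound 2 is consequently unreadable, since one of the two values sits at the limit (the limit of > 316 nM in this assay, at which 1 of the 2 values shown sits). Compound 3 `CN(CC1=CC[C@H]2C[C@@H]1C2(C)C)Cc1ccc(-c2ccoc2)cc1` differs from compound 2 in one place: furan-3-yl in place of 3-acetylphenyl on an aromatic carbon. No measured step involves a furan-3-yl, and the only step touching this position cannot be sized, so the numbers shown give no direction and no size for this change. The expected step is a step that the limit leaves unreadable from compound 2 to compound 3, with wide uncertainty on both sides. Compound 3 is estimated at 1500 nM in this assay, with a range from 250 nM to 10000 nM.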

Compound 3, inhibition constant: 6310 nM
Compound 3: the middle estimate sits 4.2-fold (0.62 log units) below what was measured, and the stated range covers the measured number.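

In this assay, for the compounds shown here, furan-3-yl in place of bromo gives a 2.0-fold higher number from compound 1 to compound 3 (0.30 log units; within the scatter), so this is the first readable comparison at this position, para to a large group, and it shows no change beyond normal assay variation. A five-membered aromatic ring and a single bromo atom therefore cannot be told apart here. Compound 2 gives only a limit, so neither step involving it can be read: the limit of > 316 nM in this assay, at which 1 of the 3 values shown sits.

The compounds shown leave open whether 3-acetylphenyl and furan-3-yl truly differ at this position, since compound 2 has no exact number to set against the others. They also leave open how an amine, a carboxylic acid or a longer carbon chain at the same position would read in this assay.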